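Working notes on a sulfonyl series, toward compound 4

The compounds below may be only part of what the source reports. "The series", "measured", "known", "first", "only" and "open" are said of these compounds alone.

Measured compounds:
compound 1 `COc1ccc(-c2cc(=O)c3c(OC)cc(OC)cc3[nH]2)cc1`: > 62000 nM
compound 2 `C=CCNC(=O)n1c(-c2ccc(OC)cc2)cc(=O)c2c(OC)cc(OC)cc21`: 74000 nM
compound 3 `COc1ccc(-c2cc(=O)c3c(OC)cc(OC)cc3n2S(=O)(=O)c2ccc([N+](=O)[O-])cc2)cc1`: > 29300 nM

The read-out throughout is an ADME assay on BJ cells (Homo sapiens) for antiproliferative activity, with a stated time of 72 h; on this read-out higher numbers stand for an effect only at larger amounts of compound and lower numbers for an effect already at smaller amounts. For compound 1 the value is only a limit of the assay (the limit of > 62000 nM in this assay, at which 1 of the 3 values shown sits). Compound 2 gives a number, and the step that the limit leaves unreadable from compound 1 to compound 2 therefore cannot be sized. For compound 3 the value is again only a limit (the limit of > 29300 nM in this assay, at which 1 of the 3 values shown sits), so compound 3 stands at the edge of what the assay reports, with no ordering against compound 1 or compound 2 readable from the numbers shown.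

Compound 4 `COc1ccc(-c2cc(=O)c3c(OC)cc(OC)cc3n2S(=O)(=O)c2cc(Cl)cc(Cl)c2O)cc1` is not yet measured. It differs from compound 3 in one place: 3,5-dichloro-2-hydroxyphenyl in place of 4-nitrophenyl on a sulfonyl sulfur. No measured step touches a change on the sulfonyl sulfur, so nothing shown speaks for or against a step in this assay beyond the scatter. The expectation is that compound 4 stays where compound 3 stands, a step that the limit leaves unreadable from compound 3 to compound 4 of no readable size, with the estimate for compound 4 at 40000 nM in the range 12000 nM to 120000 nM, and a fair chance that only a limit is reported.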

Compound 4, half-maximal effective concentration: > 37900 nM
Compound 4 ended at the assay's limit; the forecaster's own chance of this, stated with the estimate: 55%; the middle value is on the limit's open side.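

In this assay compound 4 gives > 37900 nM, a limit and not a number. Among these compounds, compound 3 gives > 29300 nM, also a limit, so no step from one to the other can be read. The compounds shown leave open whether 3,5-dichloro-2-hydroxyphenyl and 4-nitrophenyl on a sulfonyl sulfur differ at all.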